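Aryl swaps on the piperazine of a thiophene core

This account rests on a few compounds, and the source may have more. Where it says the series, first, only, none or still open, it means among the compounds named here.

Measured so far:
compound 1, `COc1ccc(N2CCN(Cc3csc(N)c3C(=O)c3ccc(Cl)cc3)CC2)cc1`: 0%
compound 2, `Nc1scc(CN2CCN(c3ccccc3F)CC2)c1C(=O)c1ccc(Cl)cc1`: 4%

In an assay on CHO cells for displacement of a labelled ligand from adenosine receptor A1 (Homo sapiens), read by scintillation counting, with a stated time of 120 min, tested at 10 uM (on this read-out higher numbers stand for more inhibition at the one concentration tested (going by the name of the read-out) and lower numbers for less inhibition), compound 1 gives 0%. Going by the values given here, compound 2 gives 4% in this assay, and the only measured step, a number 4 percentage points higher from compound 1 to compound 2 (within the scatter), does not separate the two compounds; both sit at the bottom of the read-out, and on the two numbers at hand compound 1 is not told apart from compound 2.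

Compound 3, `Nc1scc(CN2CCN(c3ccc(F)c(F)c3)CC2)c1C(=O)c1ccc(Cl)cc1`, is still to be measured. It differs from compound 1 by 3,4-difluorophenyl in place of 4-methoxyphenyl on an amine nitrogen in a ring. Among the compounds with values here, the one step that bears on this change is a number 4 percentage points higher from compound 1 to compound 2 (within the scatter), a swap of the same aryl group on the same ring nitrogen, and it was within the scatter. Nothing in the series suggests that a further aryl swap at that position would behave differently, so the expected step is a number 3 percentage points higher from compound 1 to compound 3 (within the scatter), that is, no movement beyond the scatter. For compound 3 the estimate in this assay is therefore 3%, with a range from -8% to 15%.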

Compound 3, a percentage reported as inhibition, at one concentration (the size of the read-out at that concentration, not a potency): 0%
For compound 3 the middle estimate is 3 percentage points above the measured one; the range from low to high includes it.
By their numbers in this assay, from the lowest: compounds 1, 3 and 2 (each within the scatter of the next).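

In this assay, 3,4-difluorophenyl in place of 4-methoxyphenyl on the ring nitrogen gives no change at the digits printed from compound 1 to compound 3 (within the scatter) and the same group in place of 2-fluorophenyl gives a number 4 percentage points lower from compound 2 to compound 3 (within the scatter). Three aryl groups at this position now stand within the scatter of one another at the bottom of the read-out, so the flat result no longer rests on a single pair: it also holds for a group with two fluorine atoms in place of one with the oxygen of a methoxy group, at the same count of heavy atoms. No supporting data bear on why the numbers stay this flat.

With all three values this low, the read-out gives no order among the aryl groups and does not show whether this position can influence binding to this receptor at all. Open, from the compounds shown here alone, is whether something other than an aryl group on that ring nitrogen, such as an amide, a carboxylic acid or a longer chain, would move the number beyond the scatter.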